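From 2-chlorophenyl to isopropyl on an amide-type nitrogen

This account rests on a few compounds, and the source may have more. Where it says the series, first, only, none or still open, it means among the compounds named here.

Compound 1 `CC1(C)CC(NC(=O)Nc2ccccc2Cl)c2cc(Cl)ccc2O1` gives 17000 nM
Compound 2 `CC1(C)CC(NC(=O)Nc2ccccc2Cl)c2cc(Br)ccc2O1` gives 19000 nM

Going by the values given here, in a functional assay on U-373MG ATCC cells (Homo sapiens) for inhibition, read by MTT assay, with a stated time of 72 h (a higher number here means a weaker inhibitor, a lower number a stronger inhibitor), compound 1 stands level with compound 2, the only other measured compound: the step is a 1.1-fold higher number from compound 1 to compound 2 (0.05 log units; within the scatter) for bromo in place of chloro on an aromatic carbon.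

Compound 3 `CC(C)NC(=O)NC1CC(C)(C)Oc2ccc(Cl)cc21` has not been measured. It differs from compound 1 at one place (isopropyl in place of 2-chlorophenyl on an amide-type nitrogen), with isopropyl in place of 2-chlorophenyl on an amide-type nitrogen. Among the compounds with values here, the single measured step concerns a different group, so it sets no size for this change. Nothing measured tests the loss of the 2-chlorophenyl, so the expectation is loose: a moderate move in this assay toward a higher number, meaning weaker inhibition. The expected move is a 2.6-fold higher number from compound 1 to compound 3 (0.42 log units; beyond the scatter) in size. Compound 3 is estimated at 45000 nM with a range from 18000 nM to 120000 nM as the expected span.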

Compound 3, half-maximal inhibitory concentration: 62000 nM
Compound 3: the middle estimate sits 1.4-fold (0.14 log units) below what was measured, within the range that was stated.
By their numbers in this assay, from the lowest: compounds 1 and 2 (each within the scatter of the next); then compound 3.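

In this assay, the group on the amide-type nitrogen moves the number where the halogen on the aromatic carbon did not: isopropyl in place of 2-chlorophenyl gives a 3.6-fold higher number from compound 1 to compound 3 (0.56 log units; beyond the scatter), a modest step, whereas the earlier change gave a 1.1-fold higher number from compound 1 to compound 2 (0.05 log units; within the scatter). Inhibition weakens with this change but is not lost, as compound 3 still gives a measured number of 62000 nM, so the aromatic ring and its chlorine are not essential to a measurable effect in this assay. Nothing available accounts for the size of this step.

The aromatic ring and the chlorine leave together in this change, so their separate contributions remain unresolved. An unsubstituted phenyl would separate the two, while a cyclohexyl would test the aromatic ring itself.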